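A Longer Chain on the Shared Core of Compound 2

The source may hold more compounds than are shown below. What is called first, only, known or untested is meant among the compounds shown, and "the series" means these compounds.

Compound 1, `CCCCCCCCc1cn([C@H]2C[C@H](O)[C@@H](CO)O2)c(=O)[nH]c1=O`: in a functional assay on L1210 cells (Mus musculus) (on this read-out lower numbers stand for stronger inhibition and higher numbers for weaker inhibition), compound 1 gives 66 ug/mL.
Compound 2, `CCc1cn([C@H]2C[C@@H]3OP(=O)(O)OC[C@H]3O2)c(=O)[nH]c1=O`: in this assay compound 2 gives 55 ug/mL.

The two numbers lie within the usual scatter of each other, so compound 2 stands level with compound 1 rather than apart from it. Compound 3, `CCCCCCCCc1cn([C@H]2C[C@@H]3OP(=O)(O)OC[C@H]3O2)c(=O)[nH]c1=O`, keeps the core of compound 2 and differs in one place: hexyl in place of hydrogen on a saturated chain carbon, two bonds along the chain from an aromatic carbon. For the measured compounds named here, no measured pair shows this change on its own, so its effect is unknown here. A small step is expected, a 1.1-fold lower number from compound 2 to compound 3 (0.04 log units; within the scatter), in no clear direction beyond the scatter. Compound 3 is estimated at 50 ug/mL, ranging from 15 ug/mL to 160 ug/mL.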

Compound 3, concentration for 50% inhibition: 164 ug/mL
Beside the measured number, compound 3's estimate is 3.3-fold (0.52 log units) below it; the measured number lies above the stated range.
By their numbers in this assay, from the lowest: compounds 2 and 1 (each within the scatter of the next); then compound 3.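

On the shared core, this position does respond to a change in the chain: hexyl in place of hydrogen gives a 3.0-fold higher number from compound 2 to compound 3 (0.47 log units; beyond the scatter) in this assay, a modest weakening that lies beyond the scatter. Compound 1 and compound 2 differ in more than one place, so their numbers could not show this change alone. No evidence here accounts for the weaker inhibition.

The compounds shown leave open whether a butyl chain in this place would read closer to compound 2 or to compound 3. They also leave open how a chain ending in an amine or a carboxylic acid would read.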